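The source may hold more compounds than are shown below. What is called first, only, known or untested is meant among the compounds shown, and "the series" means these compounds.

Of the compounds shown here, three built on a shared core have been measured in a functional assay on HCT-116 cells (Homo sapiens) for inhibition, read by CCK-8 assay, with a stated time of 48 h; a higher number here means a weaker inhibitor, a lower number a stronger inhibitor. Compound 1 `COc1ccc(CN(C(=O)CSC(=S)N2CCN(C)CC2)c2cc(OC)c(OC)c(OC)c2)cc1` gives 2640 nM, a true number. Compound 2 `COc1ccc(CN(C(=O)CSC(=S)N2CCN(C(=O)OC(C)(C)C)CC2)c2ccc(Cl)cc2)cc1` gives > 20000 nM, which is a limit of the assay and not a number. Compound 3 `COc1ccc(CN(C(=O)CSC(=S)N2CCN(C(=O)OC(C)(C)C)CC2)c2cc(OC)c(OC)c(OC)c2)cc1OC` gives > 20000 nM, which is also only a limit. Compound 3 therefore stands at the limit of > 20000 nM in this assay, at which 2 of the 3 values shown sit.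

Compound 4 `COc1ccc(CN(C(=O)CSC(=S)N2CCN(C(=O)OC(C)(C)C)CC2)c2cc(OC)c(OC)c(OC)c2)cc1N=[N+]=[N-]` differs from compound 3 in one place: azido in place of methoxy on an aromatic carbon. An azido group takes the place of a methoxy on an aromatic carbon, ortho to a methoxy group and meta to a large group. The same difference can be read as 3,4-dimethoxybenzyl to 3-azido-4-methoxybenzyl. All the rest of the structure stays the same.

For the measured compounds named here, no measured pair shows what this swap does, so the expectation rests mainly on the parent, compound 3, with its limit of > 20000 nM. The expected size of the change, a number no higher from compound 3 to compound 4 (the limit leaves the size open), is estimated to stay within the usual scatter, with no direction favoured. For compound 4 the estimated value is 20000 nM, with an expected range of 8000 nM to 40000 nM, and the assay may well report only a limit again.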

Compound 4, half-maximal inhibitory concentration: 780 nM
Compound 4: middle estimate off by 26-fold (1.41 log units), on the high side; measured number outside the range, below it.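

Within this assay, azido in place of methoxy on the 3,4-dimethoxybenzyl group gives an at least 25-fold lower number from compound 3 to compound 4 (1.40 log units; beyond the scatter), so this aromatic carbon, ortho to a methoxy group, is a place where a single change can matter a great deal. The two groups are alike in much of what can be counted, with no ring, no net charge, no hydrogen-bond donors and the same count of hydrogen-bond acceptors, yet the exchange is enough to bring a compound away from the limit and onto a true number. The full size of the step stays unknown, since the value for compound 3 is only a limit of the assay: the limit of > 20000 nM in this assay, at which 2 of the 4 values shown sit.

The compounds shown cannot separate a gain from azido itself from a gain from losing the methoxy, and a hydrogen, an amine or a nitrile at this carbon would help to tell these apart. From the compounds shown here alone, it also remains open whether the same swap would act similarly on the 3,4-dimethoxybenzyl group in a compound with the methyl carried by compound 1 in place of the tert-butyl carbamate.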